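This account rests on a few compounds, and the source may have more. Where it says the series, first, only, none or still open, it means among the compounds named here.

Measured compounds in an assay on isolated protein (Oryctolagus cuniculus) for inhibition of Calpain-2 catalytic subunit (Homo sapiens); on this read-out lower numbers stand for stronger inhibition and higher numbers for weaker inhibition:
- compound 1 `CCC(NC(=O)C(CC(C)C)NC(=O)OCc1ccccc1)C(=O)C(=O)NCc1nccc2ccccc12`: compound 1 gives 150 nM
- compound 2 `CCNC(=O)C(=O)C(CC)NC(=O)C(CC(C)C)NC(=O)c1ccc2ccccc2n1`: compound 2 gives 300 nM
- compound 3 `CCNC(=O)C(=O)C(CC)NC(=O)C(CC(C)C)NC(=O)c1nccc2ccccc12`: compound 3 gives 110 nM

Compound 3 holds the lowest number of the three. Its gap to compound 1 lies within the scatter, so the two are not separable; its gap to compound 2 is real, as the step of a 2.7-fold lower number from compound 2 to compound 3 (0.44 log units; beyond the scatter) shows for the exchange of one bicyclic aromatic cap on the carbonyl carbon for another.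

Compound 4 `CCNC(=O)C(=O)C(CC)NC(=O)C(CC(C)C)NC(=O)N1CCOCC1` is not yet measured. Relative to compound 3 the change is morpholin-4-yl in place of isoquinolin-1-yl on a carbonyl carbon. Among the measured compounds shown here, the only measured step at this position is the one from compound 2 to compound 3, a modest one between two aromatic caps; compound 1 shows that a non-aromatic cap on the same carbonyl carbon in a related core gives a number close to compound 3. For the measured compounds named here, no step in the set removes the aromatic rings entirely. The step of a 2.7-fold higher number from compound 3 to compound 4 (0.44 log units; beyond the scatter) is therefore expected to be small to modest, toward a higher number, with the possibility that it stays within the scatter. For compound 4 the estimate in this assay is 300 nM, with a range from 100 nM to 1000 nM.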

Compound 4, inhibition constant: 9900 nM
Compound 4: middle estimate off by 33-fold (1.52 log units), on the low side; measured number above the stated range.
By their numbers in this assay, from the lowest: compounds 3, 1 and 2 (each within the scatter of the next, the first and the last beyond it); then compound 4.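

In this assay the exchange of an aromatic cap for morpholin-4-yl on this carbonyl carbon gives a 90-fold higher number from compound 3 to compound 4 (1.95 log units; beyond the scatter) and, starting from the other aromatic cap, a 33-fold higher number from compound 2 to compound 4 (1.52 log units; beyond the scatter) in the same direction. Both steps are much larger than a 2.7-fold lower number from compound 2 to compound 3 (0.44 log units; beyond the scatter) between the two aromatic caps, so among compounds 2, 3 and 4 this position responds far more to the loss of the aromatic rings than to the choice of isoquinolin-1-yl or quinolin-2-yl. No measurement at hand bears on why the number rises so sharply with this change.

The change from either aromatic cap to morpholin-4-yl removes both aromatic rings, reduces the heavy-atom count and brings in a ring oxygen all at once, so the compounds shown cannot assign the rise to any one of these. A single phenyl ring on the same carbonyl carbon, or a piperidin-1-yl ring in place of morpholin-4-yl, would separate these parts of the change, and neither group is among the compounds shown here.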